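The source may hold more compounds than are shown below. What is called first, only, known or untested is meant among the compounds shown, and "the series" means these compounds.

The study concerns three coumarin-type ethers measured in an assay on isolated protein (strain Sprague-Dawley) for inhibition of Amine oxidase [flavin-containing] A (Rattus norvegicus), read by spectrophotometry, with a stated time of 5 min, tested at 10 uM; on this read-out lower numbers stand for less inhibition and higher numbers for more inhibition at the one concentration tested (going by the name of the read-out). For the measured compounds named here, compound 1 `O=c1cc(O)c2ccc(OCc3cccc(Br)c3)cc2o1` gives 0% in this assay, while compound 2 `COc1cc(=O)oc2cc(OCc3cccc(Br)c3)ccc12`, which carries methyl in place of hydrogen on an oxygen on an aromatic ring, gives 27%; the step of a number 27 percentage points higher from compound 1 to compound 2 (beyond the scatter) is the only single-point change that has been measured. Compound 3 `O=c1cc(CCl)c2ccc(OCc3cccc(Cl)c3)cc2o1` gives 21% in this assay, a value that lies within the scatter of the value of compound 2 and beyond the scatter above the value of compound 1.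

Compound 4 `O=c1cc(CCl)c2ccc(OCc3cccc(Br)c3)cc2o1` differs from compound 3 by bromo in place of chloro on an aromatic carbon. Going by the values given here, no measured step bears directly on this exchange of one halogen for another: the one measured step concerns a methyl on an oxygen, not the halogen on the phenyl ring, and compounds 1 and 2 both already carry the bromo group. With nothing to suggest a shift, the step of a number 1 percentage points higher from compound 3 to compound 4 (within the scatter) is expected to stay within the scatter. Compound 4 is therefore estimated to give 22% in this assay, with a plausible range from 8% to 38%.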

Compound 4, a percentage reported as inhibition, at one concentration (the size of the read-out at that concentration, not a potency): 28%
Estimate against measurement, compound 4: 6 percentage points below; measured number inside the range.
By their numbers in this assay, from the lowest: compound 1; then compounds 3, 2 and 4 (each within the scatter of the next).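

In this assay, for the compounds shown here, the change from 3-chlorophenyl to 3-bromophenyl gives a number 7 percentage points higher from compound 3 to compound 4 (within the scatter) and is the first measured exchange on this ring, so at this place bromo and chloro are not told apart. On the shared core, chloromethyl in place of methoxy gives only a number 1 percentage points higher from compound 2 to compound 4 (within the scatter) while chloromethyl in place of hydroxy gives a number 28 percentage points higher from compound 1 to compound 4 (beyond the scatter) and so among the bromo compounds only the hydroxy compound 1 stands apart. No independent evidence accompanies these numbers to account for them.

On these data alone, whether an amine, a carboxylic acid or a longer chain in the place of the chloromethyl would read like the methoxy compound or like the hydroxy compound remains open. Also open, as far as these compounds go, is how fluoro on the same aromatic carbon would read, and how these compounds compare in potency, since the read-out covers a single concentration.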